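The source may report more compounds than this note shows. Statements on the series, on what has been measured and on what is new or still open speak of the compounds shown alone.

Measured compounds:
- compound 1 `O=C(O)c1csc([C@H]2CC[C@@H]3[C@@H](COc4ccc(C(F)(F)F)cc4)[C@H](O)C[C@@H]3O2)n1`: 13 nM
- compound 2 `O=C(O)c1csc([C@H]2CC[C@@H]3[C@@H](COc4cccc(Cl)c4)[C@H](O)C[C@@H]3O2)n1`: 6.5 nM
- compound 3 `O=C(O)c1csc([C@H]2CC[C@@H]3[C@@H](COc4cccc(OC(F)(F)F)c4)[C@H](O)C[C@@H]3O2)n1`: 0.9 nM

In a functional assay on CHO cells for agonist activity at prostaglandin E2 receptor EP2 subtype (Homo sapiens), read by HTRF and cAMP accumulation, with a stated time of 30 min (on this read-out higher numbers stand for an effect only at larger amounts of compound and lower numbers for an effect already at smaller amounts), compound 2 stands second highest of the three numbers, nearest to compound 1 and furthest from compound 3. Compound 4 `O=C(O)c1csc([C@H]2CC[C@@H]3[C@@H](CCOc4ccccc4)[C@H](O)C[C@@H]3O2)n1` differs from compound 2 by phenoxymethyl in place of 3-chlorophenoxy on a saturated chain carbon bound to a saturated ring carbon. The steps seen so far, a 2.0-fold lower number from compound 1 to compound 2 (0.30 log units; within the scatter) and a 7.2-fold lower number from compound 2 to compound 3 (0.86 log units; beyond the scatter), both swap one aromatic substituent for another while the chain stays the same, so neither bears directly on a longer chain without a chloro. With no guide for the chain change, compound 4 is expected to give roughly 20 nM, between 4 nM and 100 nM, meaning a 3.1-fold higher number from compound 2 to compound 4 (0.49 log units; beyond the scatter) as a weak expectation.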

Compound 4, half-maximal effective concentration: 1.4 nM
Estimate against measurement, compound 4: 14-fold (1.15 log units) above, and the stated range ends above it.
By their numbers in this assay, from the lowest: compounds 3 and 4 (each within the scatter of the next); then compounds 2 and 1 (each within the scatter of the next).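

In this assay replacing (3-chlorophenoxy)methyl with 2-phenoxyethyl gives a 4.6-fold lower number from compound 2 to compound 4 (0.67 log units; beyond the scatter) and so shows that this position tolerates a change to the chain itself, not only to substituents on the aromatic ring. The swap lengthens the chain and removes the chlorine together, so this step cannot divide its size between those two changes. No measured evidence here explains the step.

A 2-(3-chlorophenoxy)ethyl group would carry the longer chain with the chlorine kept. As far as these compounds go, whether a still longer 3-phenoxypropyl chain fits this trend remains open.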